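One ring swap in a pair of weakly cytotoxic compounds

A few compounds are considered here, and "the series" means these few. Any claim that something is new, unique, unknown or untested is made for them only; others in the source may bear on it.

Compound 2 `FC(F)(F)Oc1ccc(-c2cc(COc3ccccc3-c3nc4ccccc4s3)on2)cc1` and compound 1 `FC(F)(F)C(F)(F)C(F)(F)C(F)(F)C(F)(F)C(F)(F)C(F)(F)C(F)(F)CCn1cc(COc2ccccc2-c2nc3ccccc3s2)nn1` were both tested in an ADME assay on MCF-10A cells (Homo sapiens) for cytotoxicity, read by MTT assay, with a stated time of 24 h; on this read-out higher numbers stand for weaker inhibition and lower numbers for stronger inhibition. Compound 2 gives 43900 nM, and compound 1 gives 33100 nM; the two numbers lie within the usual scatter of each other. Compound 3 `Fc1ccccc1-c1cc(COc2ccccc2-c2nc3ccccc3s2)on1` differs from compound 2 in one place: 2-fluorophenyl in place of 4-(trifluoromethoxy)phenyl on an aromatic carbon. For the measured compounds named here, no measured step between related compounds exists to lean on, and the two known numbers sit close together, so the expected step from compound 2 to compound 3 is a 1.0-fold higher number from compound 2 to compound 3 (0.01 log units; within the scatter), none beyond the scatter. Compound 3 is therefore estimated at 45000 nM, within 20000 nM to 100000 nM.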

Compound 3, half-maximal inhibitory concentration: 42500 nM
Beside the measured number, compound 3's estimate is 1.1-fold (0.02 log units) above it; the range from low to high includes it.
By their numbers in this assay, from the lowest: compounds 1, 3 and 2 (each within the scatter of the next).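

In this assay, 2-fluorophenyl in place of 4-(trifluoromethoxy)phenyl, on the aromatic carbon next to the ring nitrogen, gives a 1.0-fold lower number from compound 2 to compound 3 (0.01 log units; within the scatter). For the compounds shown here, this is the first one-place comparison at this position, and the read-out does not separate these two phenyl groups. Nothing available here explains this result.

On these data alone, whether an amine or a carboxylic acid on this carbon would give a number beyond the scatter remains open. So does whether 4-fluorophenyl or unsubstituted phenyl would match these two groups.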